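Benzyl Replaces 4-Ethylphenyl on the Amine Nitrogen

The source may report more compounds than this note shows. Statements on the series, on what has been measured and on what is new or still open speak of the compounds shown alone.

Compound 1 `CCc1ccc(NC2=CC(=O)c3c(nc4n3[C@H]3OC[C@@H](O)[C@H]3OC4)C2=O)cc1`: 6510 nM
Compound 2 `O=C1C=C(NC2CCCCC2)C(=O)c2c1nc1n2[C@H]2OC[C@@H](O)[C@H]2OC1`: > 16000 nM, a limit of the assay and not a number
Compound 3 `Cc1ccc(NC2=CC(=O)c3nc4n(c3C2=O)[C@H]2OC[C@@H](O)[C@H]2OC4)cc1C`: 2690 nM

All values come from a functional assay on HeLa cells (Homo sapiens) for inhibition, read by sulforhodamine B assay; a higher number here means a weaker inhibitor, a lower number a stronger inhibitor. Compound 1 holds the highest of the two numbers given; the nearest is compound 3, whose lower number lies beyond the scatter. Compound 2 reports only a limit, (the limit of > 16000 nM in this assay, at which 1 of the 3 values shown sits). Compound 4 `O=C1C(NCc2ccccc2)=CC(=O)c2c1nc1n2[C@H]2OC[C@@H](O)[C@H]2OC1` differs from compound 1 by benzyl in place of 4-ethylphenyl on an amine nitrogen. Among the compounds with values here, the one measured step that bears on this change is an at least 5.9-fold lower number from compound 2 to compound 3 (0.77 log units; beyond the scatter), where an aromatic ring took the place of a saturated one on the amine nitrogen and the number fell. Compound 4 moves partly the other way, so a step toward a higher number is expected, a 1.7-fold higher number from compound 1 to compound 4 (0.23 log units; within the scatter). Compound 4 is therefore estimated at 11000 nM, within 4000 nM to 30000 nM.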

Compound 4, half-maximal inhibitory concentration: 11000 nM
Compound 4: middle estimate and measured number agree at the digits printed; measured number inside the range.
By their numbers in this assay, from the lowest: compound 3; then compounds 1 and 4 (each within the scatter of the next). At a limit, above all of these: compound 2.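

In this assay, benzyl in place of 4-ethylphenyl on the amine nitrogen gives a 1.7-fold higher number from compound 1 to compound 4 (0.23 log units; within the scatter), so this pair shows no change at this position that can be told from the scatter. Both groups carry a six-membered aromatic ring of carbon only, and here the rest of the group could change without a resolved shift. Nothing measured here accounts for this step.

Going by these compounds, whether a longer chain on the amine nitrogen, or a carboxylic acid on the aromatic ring, would shift the number remains open.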